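The source may report more compounds than this note shows. Statements on the series, on what has been measured and on what is new or still open speak of the compounds shown alone.

Compound 3 `c1ccc2c(c1)CN[C@@H](CN(CCCN1CCNCC1)[C@H]1CCCc3cccnc31)C2` stands highest of the three measured compounds in an ADME assay on microsomes from liver (Homo sapiens) for metabolic stability, read by LC-MS, with a stated time of 10 min, tested at 0.5 uM (a lower number here means that less of the compound is left, a higher number that more of the compound is left), where compound 3 gives 100%. In this assay compound 1 `CC(C)N1CCN(CCCN(C[C@H]2Cc3ccccc3CN2)[C@H]2CCCc3cccnc32)CC1` gives 46% and compound 2 `CCN1CCN(CCCN(C[C@H]2Cc3ccccc3CN2)[C@H]2CCCc3cccnc32)CC1` gives 59%. Compound 4 `NC(=O)N1CCN(CCCN(C[C@H]2Cc3ccccc3CN2)[C@H]2CCCc3cccnc32)CC1` differs from compound 3 by carbamoyl in place of hydrogen on an amine nitrogen in a ring. Going by the values given here, two measured steps bear on this change, both at the same ring nitrogen: a number 54 percentage points higher from compound 1 to compound 3 (beyond the scatter), and a number 41 percentage points higher from compound 2 to compound 3 (beyond the scatter). Both show a bare ring nitrogen giving a far higher number than one carrying an alkyl group. Carbamoyl is not an alkyl group, yet a group again enters at that nitrogen, so compound 4 is expected to show a downward step, a number 25 percentage points lower from compound 3 to compound 4 (beyond the scatter). Compound 4 is estimated at 75%, within 45% to 100%.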

Compound 4, percent of the compound remaining: 79%
Compound 4: the middle estimate sits 4 percentage points below what was measured; the measured number falls inside the stated range.
By their numbers in this assay, from the lowest: compound 1; then compound 2; then compound 4; then compound 3.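

In this assay, a group at this ring nitrogen need not bring the full drop seen with the alkyl groups: carbamoyl gives a number 21 percentage points lower from compound 3 to compound 4 (beyond the scatter). Carbamoyl also stands above both alkyl groups, with a number 20 percentage points higher from compound 2 to compound 4 (beyond the scatter) and a number 33 percentage points higher from compound 1 to compound 4 (beyond the scatter), so the identity of the entering group matters, not only the presence of one. Nothing measured here gives a reason for this order. As far as these compounds go, whether an acetyl group, a methyl group or a short chain ending in a carboxylic acid at this nitrogen would land nearer compound 3 or compound 1 stays open.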